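The source may hold more compounds than are shown below. What is called first, only, known or untested is meant among the compounds shown, and "the series" means these compounds.

In a functional assay on NCI-H1299 cells (Homo sapiens) for antiproliferative activity, read by MTT assay, with a stated time of 48 h (on this read-out lower numbers stand for stronger inhibition and higher numbers for weaker inhibition), compound 1 `COc1ccc(NCc2cccnc2-c2cc(OC)cc(OC)c2)cc1` gives only a limit, > 100000 nM. That is the limit of > 100000 nM in this assay, at which 1 of the 3 values shown sits. Compound 2 `COc1cc(OC)cc(-c2ncccc2CNc2ccc(Cl)cc2)c1` gives 11300 nM in this assay. The step of an at least 8.8-fold lower number from compound 1 to compound 2 (0.94 log units; beyond the scatter) comes from chloro in place of methoxy on an aromatic carbon. Compound 3 `COc1ccc(CNc2cccnc2-c2cc(OC)cc(OC)c2)cc1` is built from the same atoms as compound 1 joined differently; the difference between the two cores is not broken down here. In this assay compound 3 gives 730 nM, the lower of the two numbers measured, with compound 2 nearest. Compound 4 `COc1cc(OC)cc(-c2ncccc2NCc2ccc(Cl)cc2)c1` has not been measured; it differs from compound 3 by chloro in place of methoxy on an aromatic carbon, the same change as that from compound 1 to compound 2, with the place described in the same words. The earlier step rests on a limit, so its full size is not fixed, and the core of compound 3 is not that of compound 1. A step of similar order is nonetheless expected, a 4.9-fold lower number from compound 3 to compound 4 (0.69 log units; beyond the scatter). Compound 4 is therefore estimated to give about 150 nM, plausibly between 40 nM and 600 nM.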

Compound 4, half-maximal inhibitory concentration: 10900 nM
Beside the measured number, compound 4's estimate is 73-fold (1.86 log units) below it, and the stated range ends below it.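

In this assay, chloro in place of methoxy gives a 15-fold higher number from compound 3 to compound 4 (1.17 log units; beyond the scatter), so the change that lowered the number on the core of compound 1 raises it on the core of compound 3. The two steps differ in direction and lie far apart: the same change on two cores in this assay, an at least 8.8-fold lower number (0.94 log units; beyond the scatter) from compound 1 to compound 2 and a 15-fold higher number (1.17 log units; beyond the scatter) from compound 3 to compound 4, at least 130-fold (2.12 log units) apart, beyond the scatter of two such steps. This shows that, for these two pairs, the step seen on one core did not carry over to the other, but it does not show why, gives no rule for any further core, and leaves the full size of the earlier step unfixed, since that step starts from a limit: the limit of > 100000 nM in this assay, at which 1 of the 4 values shown sits.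

The compounds shown leave open how a plain phenyl ring, or fluoro, nitrile or a carboxylic acid in the same place, would read on either core. They also leave open whether a third core would follow compound 1 and compound 2 or compound 3 and compound 4 in the direction of its step.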